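This account rests on a few compounds, and the source may have more. Where it says the series, first, only, none or still open, it means among the compounds named here.

Series notes. Compound 1, `S=C(SCc1nc2cc(Cl)c(Cl)cc2[nH]1)N1CCCCC1`, gives 42800 nM in a functional assay on MCF7 cells (Homo sapiens) for cytotoxicity, read by MTT assay, with a stated time of 24 h; on this read-out higher numbers stand for weaker inhibition and lower numbers for stronger inhibition. Compound 2, `CCOc1ccccc1N1CCN(C(=S)SCc2nc3cc(Cl)c(Cl)cc3[nH]2)CC1`, gives 16200 nM in this assay. For the measured compounds named here, of the two numbers measured so far, compound 2 holds the lower one, and the gap between compound 2 and compound 1 lies beyond the usual scatter of repeated runs. Compound 3, `S=C(SCc1nc2cc(Cl)c(Cl)cc2[nH]1)N1CCN(c2ccccc2Cl)CC1`, has not yet been measured. It differs from compound 2 in one place: chloro in place of ethoxy on an aromatic carbon. Going by the values given here, no pair of measured compounds differs at this position, so there is no measured step to lean on. The change is confined to the group on the six-membered aromatic ring of carbon only, with the shared core unchanged; the step of a 1.1-fold higher number from compound 2 to compound 3 (0.05 log units; within the scatter) is expected to be small, within the scatter of the method, with no clear direction. Compound 3 is estimated at about 18000 nM in this assay, with a range of 8000 nM to 40000 nM.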

Compound 3, half-maximal inhibitory concentration: 60200 nM
For compound 3 the middle estimate is 3.3-fold (0.52 log units) below the measured one, outside the stated range (above it).
By their numbers in this assay, from the lowest: compound 2; then compounds 1 and 3 (each within the scatter of the next).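

In this assay the change from 2-ethoxyphenyl to 2-chlorophenyl gives a 3.7-fold higher number from compound 2 to compound 3 (0.57 log units; beyond the scatter), so this carbon, ortho to a large group, is not indifferent to what it carries, and of the two groups ethoxy goes with the stronger inhibition. For the compounds shown here, this is the first measured step at this position, and it rests on one pair of compounds, so it supports no wider pattern across substituents. Nothing available here accounts for the size or direction of this step. The compounds shown leave open how methoxy, a longer alkoxy chain or an amine would read at this carbon. They also leave open whether ethoxy and chloro would keep this order on another carbon of the same ring.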